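A Small Change at the Chain End: Compound 1 to 3

The source may hold more compounds than are shown below. What is called first, only, known or untested is meant among the compounds shown, and "the series" means these compounds.

Compound 1 `NC(=O)C(=O)NCCCCCC(=O)Nc1ccccc1` was tested in a functional assay on HCT-116 cells (Homo sapiens) for inhibition, read by colorimetric assay, with a stated time of 3 days (a lower number here means a stronger inhibitor, a higher number a weaker inhibitor), where compound 1 reaches only the limit > 100000 nM. Compound 2 `COc1ccc(NC(=O)CCCCCCNC(=O)C(O)(O)C(F)(F)F)cc1` gives in this assay a value of 4520 nM. For the measured compounds named here, no two measured compounds differ in a single place, so no measured step is available. Compound 3 `C/C(=N\O)C(=O)NCCCCCC(=O)Nc1ccccc1` differs from compound 1 by a group of 4 heavy atoms (2 carbon, 1 nitrogen, 1 oxygen; no ring) in place of a group of 3 heavy atoms (1 carbon, 1 nitrogen, 1 oxygen; no ring), on a carbonyl carbon. Because compound 1 sits at the limit (the limit of > 100000 nM in this assay, at which 1 of the 2 values shown sits), the step to compound 3 cannot be read from the data, and no change beyond the scatter is expected. For compound 3 the estimate is 90000 nM, between 20000 nM and 300000 nM, an expected step of an at least 1.1-fold lower number from compound 1 to compound 3 (0.04 log units; that floor lies within the scatter).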

Compound 3, half-maximal inhibitory concentration: > 100000 nM
Compound 3 was reported as a limit (the forecaster's own chance of this, stated with the estimate: 65%); middle value at least 1.1-fold (0.04 log units) from the limit.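

Compound 1 and compound 3 are both reported only as limits, so no step between them can be read: the limit of > 100000 nM in this assay, at which 2 of the 3 values shown sit.

What the compounds shown leave open is whether, in this assay, any other group on that carbonyl carbon of compound 1 would give a value rather than a limit.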